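This account rests on a few compounds, and the source may have more. Where it says the series, first, only, none or still open, it means among the compounds named here.

In a physicochemical assay for solubility, at pH 2 (on this read-out higher numbers stand for higher solubility and lower numbers for lower solubility), compound 1 `CNc1nc(N2CCC(N)CC2)c2sc(-c3ccc(C(F)(F)F)cc3)cc2n1` gives > 200 ug/mL, which is the upper limit of the assay rather than a measured number (the limit of > 200 ug/mL in this assay, at which 1 of the 2 values shown sits). Compound 2 `CNc1nc(NC2CCOCC2)c2sc(-c3ccc(C(F)(F)F)cc3)cc2n1` carries (oxan-4-yl)amino in place of 4-aminopiperidin-1-yl on an aromatic carbon. In this assay compound 2 gives < 5 ug/mL, again a limit of the assay and not a number (the limit of < 5 ug/mL in this assay, at which 1 of the 2 values shown sits). That exchange produced an at least 40-fold lower number from compound 1 to compound 2 (1.60 log units; beyond the scatter). Compound 3 `Nc1nc(N2CCC(N)CC2)c2sc(-c3ccc(C(F)(F)F)cc3)cc2n1` differs from compound 1 at another place: hydrogen in place of methyl on a nitrogen on an aromatic ring. Within the data shown here, the one measured step changes a different part of the shared core and leaves no direct guide for removing a methyl; the 4-aminopiperidin-1-yl group of compound 1 stays in place. With compound 1 already at its limit in this assay, the step from compound 1 to compound 3 is expected to be a step that the limit leaves unreadable from compound 1 to compound 3, nothing beyond the scatter. Compound 3 is estimated at 250 ug/mL, within a range from 150 ug/mL to 500 ug/mL, and will most likely be reported as a limit again.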

Compound 3, solubility: 134 ug/mL
For compound 3 the middle estimate is 1.9-fold (0.27 log units) above the measured one; measured number below the stated range.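

Among these compounds, compound 3 is the first compound here to give a measured number in this assay rather than a limit, so the series now has a value against which further changes at this nitrogen can be read. Hydrogen in place of methyl on the nitrogen gives an at least 1.4-fold lower number from compound 1 to compound 3 (0.17 log units; that floor lies within the scatter) and so shows no change that can be told from the scatter. Going by these compounds, that figure is only a floor, and the true size of the step stays unknown, as compound 1 rests on a limit of the assay: the limit of > 200 ug/mL in this assay, at which 1 of the 3 values shown sits.

On these data alone, whether an ethyl group or a longer chain on this nitrogen would shift the read-out remains open. So does the reading of a piperazine in place of the 4-aminopiperidin-1-yl group on compound 3.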